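A few compounds are considered here, and "the series" means these few. Any claim that something is new, unique, unknown or untested is made for them only; others in the source may bear on it.

In an assay on isolated protein for inhibition of annexin A2/S100-A10 (Homo sapiens), with a stated time of 5 min, tested at 50 uM (on this read-out lower numbers stand for less inhibition and higher numbers for more inhibition at the one concentration tested (going by the name of the read-out)), three compounds sharing one core have been measured. Compound 1 `Cc1ccc(C(=O)C2=C(O)C(=O)N(CC(C)O)C2c2cccc(C(C)C)c2)cc1` gives 100%, compound 2 `CCCc1ccc(C2C(C(=O)c3ccc(C)cc3)=C(O)C(=O)N2CC(C)O)cc1` gives 97%, and compound 3 `Cc1ccc(C(=O)C2=C(O)C(=O)N(CC(C)O)C2c2cccc(C(F)(F)F)c2)cc1` gives 110%. Compound 3 stands apart from compound 2 by a number 13 percentage points higher from compound 2 to compound 3 (beyond the scatter), whereas against compound 1 the gap is a number 10 percentage points higher from compound 1 to compound 3 (within the scatter). Compound 4 `Cc1ccc(C(=O)C2=C(O)C(=O)N(CC(C)O)C2c2cc(C(F)(F)F)cc(C(F)(F)F)c2)cc1` differs from compound 3 by trifluoromethyl in place of hydrogen on an aromatic carbon. Among the compounds with values here, the one earlier step that touched this aromatic carbon, a number 10 percentage points higher from compound 1 to compound 3 (within the scatter), was small, and compound 3 already has the highest number of the three, so only a small step, or none beyond the scatter, is expected in this assay. For compound 4 the expected step is a number 2 percentage points lower from compound 3 to compound 4 (within the scatter). Compound 4 is thus estimated at 108%, within a range of 95% to 120%.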

Compound 4, a percentage reported as inhibition, at one concentration (the size of the read-out at that concentration, not a potency): 109%
Estimate against measurement, compound 4: 1 percentage points below; the measured number falls inside the stated range.
By their numbers in this assay, from the lowest: compounds 2, 1, 4 and 3 (each within the scatter of the next, the first and the last beyond it).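

In this assay this aromatic carbon carries a second trifluoromethyl in place of hydrogen with a number 1 percentage points lower from compound 3 to compound 4 (within the scatter) as the whole step, so the added 4 heavy atoms leave the reading unchanged within the scatter. The earlier compounds shown here varied a group already on the ring, whereas this one shows that a further ring carbon can also take a large group at this single concentration. Nothing measured here explains this result. As far as these compounds go, whether an amine or a carboxylic acid on this carbon would move the number stays open, as does whether compound 3 and compound 4 would differ across several concentrations.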